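Adding a fluorine to the aryl ring of an agonist series

The source may report more compounds than this note shows. Statements on the series, on what has been measured and on what is new or still open speak of the compounds shown alone.

Compound 1 `CC(C)OC(=O)N1CCC(n2ncc3cc(-c4ccc(C(N)=O)cc4F)ncc32)CC1` and compound 2 `CC(C)OC(=O)N1CCC(n2ncc3cc(-c4cc(F)c(C(N)=O)cc4F)ncc32)CC1` differ by fluoro in place of hydrogen on an aromatic carbon. In a functional assay on HEK293 cells for agonist activity at Glucose-dependent insulinotropic receptor (Homo sapiens), read by cAMP accumulation, with a stated time of 30 min (on this read-out lower numbers stand for an effect already at smaller amounts and higher numbers for an effect only at larger amounts of compound), compound 1 gives 97 nM and compound 2 gives 52 nM, so the step of a 1.9-fold lower number from compound 1 to compound 2 (0.27 log units; within the scatter).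

Compound 3 `CC(C)(OC(=O)N1CCC(n2ncc3cc(-c4ccc(S(C)(=O)=O)cc4)ncc32)CC1)C(F)F` carries a different core; the difference between its core and that of compound 1 is not broken down here. In this assay compound 3 gives 23 nM.

Compound 4 `CC(C)(OC(=O)N1CCC(n2ncc3cc(-c4ccc(S(C)(=O)=O)cc4F)ncc32)CC1)C(F)F` is related to compound 3 by fluoro in place of hydrogen on an aromatic carbon. This is the same kind of change as from compound 1 to compound 2, but not the same: in compound 2 the fluoro sits ortho to a carbamoyl group, meta to a large group and para to a fluoro group, whereas in compound 4 it sits ortho to a large group and meta to a methylsulfonyl group.

The step to compound 4 is expected to be small, a 1.4-fold lower number from compound 3 to compound 4 (0.16 log units; within the scatter), because the earlier step of a 1.9-fold lower number from compound 1 to compound 2 (0.27 log units; within the scatter) was itself within the scatter. Compound 4 is estimated at 16 nM, between 7 nM and 45 nM.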

Compound 4, half-maximal effective concentration: 10 nM
Estimate against measurement, compound 4: 1.6-fold (0.20 log units) above; the range from low to high includes it.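

Turning the 4-(methylsulfonyl)phenyl of compound 3 into the 2-fluoro-4-(methylsulfonyl)phenyl of compound 4 gives, in this assay, a 2.3-fold lower number from compound 3 to compound 4 (0.36 log units; beyond the scatter). Set beside the earlier step, the change lowers the number in both cases, and the two steps are of similar size: the same change on two cores in this assay, a 1.9-fold lower number (0.27 log units; within the scatter) from compound 1 to compound 2 and a 2.3-fold lower number (0.36 log units; beyond the scatter) from compound 3 to compound 4, 1.2-fold (0.09 log units) apart, within the scatter of two such steps This shows only that the step stayed similar across these two pairs, with the fluoro in a different place relative to the other ring groups in each; it does not show that the same step would appear on any further core, and the earlier step taken alone lies within the scatter.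

On these data alone, it remains open whether another small group at the same place on the ring, such as chloro, methyl or methoxy, would give a step like the one seen with fluoro. As far as these compounds go, it also remains open whether the fluoro step would hold if a nitrile or a carboxylic acid stood in place of the methylsulfonyl or carbamoyl group.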